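Amino in place of chloro on a dichloropurine core

A few compounds are considered here, and "the series" means these few. Any claim that something is new, unique, unknown or untested is made for them only; others in the source may bear on it.

In a functional assay on EKVX cells (Homo sapiens) for cytotoxicity, read by sulforhodamine B assay, with a stated time of 48 h (on this read-out lower numbers stand for higher toxicity in this test and higher numbers for lower toxicity in this test), the measured compounds are:
compound 1, `ClCc1ccccc1Cn1cnc2c(Cl)nc(Cl)nc21`, 5880 nM
compound 2, `ClCc1cccc(Cn2cnc3c(Cl)nc(Cl)nc32)c1`, 6450 nM
compound 3, `Nc1nc(Cl)c2ncn(Cc3ccccc3CCl)c2n1`, 60300 nM

Compound 1 and compound 2 are built from the same atoms joined differently; the difference between their two cores is not broken down here. Their two numbers in this assay lie within the usual scatter of one another, so nothing can be said about an order between them. Compound 3 differs from compound 1 by amino in place of chloro on an aromatic carbon, and that change gave a 10-fold higher number from compound 1 to compound 3 (1.01 log units; beyond the scatter).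

Compound 4, `Nc1nc(Cl)c2ncn(Cc3cccc(CCl)c3)c2n1`, has not yet been measured. It differs from compound 2 by amino in place of chloro on an aromatic carbon; the surroundings of the changed carbon are the same as in the change from compound 1 to compound 3, so this is the same change made on the core of compound 2. Going by the values given here, because the one measured instance of this change gave a 10-fold higher number from compound 1 to compound 3 (1.01 log units; beyond the scatter), a step of a 9.3-fold higher number from compound 2 to compound 4 (0.97 log units; beyond the scatter) is expected here. Compound 4 is therefore estimated at 60000 nM, with a likely range from 25000 nM to 150000 nM.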

Compound 4, concentration lethal to 50% of the cells: 60300 nM
Compound 4: middle estimate off by 1.0-fold (0.00 log units), on the low side; the range from low to high includes it.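

Amino in place of chloro on the core of compound 2 gave a 9.3-fold higher number from compound 2 to compound 4 (0.97 log units; beyond the scatter) in this assay. Set beside the earlier instance, the change carried over from one core to the other with its size preserved: the same change on two cores in this assay, a 10-fold higher number (1.01 log units; beyond the scatter) from compound 1 to compound 3 and a 9.3-fold higher number (0.97 log units; beyond the scatter) from compound 2 to compound 4, 1.1-fold (0.04 log units) apart, within the scatter of two such steps. Going by these compounds alone, this agreement rests on only two pairs of compounds in a single assay, so it does not show that the step would hold on any other core or in any other cells, and it gives no explanation for the step.

The four compounds carry only chloro or amino on the changed carbon, leaving open how a methylamino, hydroxyl or methoxy group there would compare in this assay. The chloromethyl group is present in all four compounds, so they also leave open whether the step would persist if a methyl or hydroxymethyl group stood in its place.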